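Ortho substituent swap on the shared core: from trifluoromethyl to phenoxy

A few compounds are considered here, and "the series" means these few. Any claim that something is new, unique, unknown or untested is made for them only; others in the source may bear on it.

Of the compounds shown here, three sharing the same core have been tested in a functional assay on WI-38 VA13 cells (Homo sapiens) for cytotoxicity; on this read-out higher numbers stand for an effect only at larger amounts of compound and lower numbers for an effect already at smaller amounts. Compound 1 `O=C(Nc1ccc2nc(NC(=O)C3CCCCC3)sc2c1)c1ccccc1F` gives 0.14 ug/mL. Compound 2 `O=C(Nc1ccc2nc(NC(=O)C3CCCCC3)sc2c1)c1ccccc1Cl` gives 0.025 ug/mL. Compound 3 `O=C(Nc1ccc2nc(NC(=O)C3CCCCC3)sc2c1)c1ccccc1C(F)(F)F` gives 0.024 ug/mL, the lowest of the three numbers, although compound 2 sits within the scatter of it, so the two cannot be ranked. The steps measured so far are a 5.6-fold lower number from compound 1 to compound 2 (0.75 log units; beyond the scatter), a 5.8-fold lower number from compound 1 to compound 3 (0.77 log units; beyond the scatter) and a 1.0-fold lower number from compound 2 to compound 3 (0.02 log units; within the scatter).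

Compound 4 `O=C(Nc1ccc2nc(NC(=O)C3CCCCC3)sc2c1)c1ccccc1Oc1ccccc1` differs from compound 3 in one place: phenoxy in place of trifluoromethyl on an aromatic carbon. For the measured compounds named here, no measured step covers this exact exchange. The two steps that start from compound 1 show that replacing fluoro with either chloro or trifluoromethyl lowered the number to a modest degree, while the exchange between chloro and trifluoromethyl changed nothing beyond the scatter. Going by the values given here, with no direct precedent, the expectation for compound 4 is a number near that of compound 3, with no step beyond the scatter, which is the step of a 1.3-fold higher number from compound 3 to compound 4 (0.10 log units; within the scatter). Compound 4 is therefore estimated at 0.03 ug/mL, within a range from 0.008 ug/mL to 0.12 ug/mL.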

Compound 4, half-maximal effective concentration: 0.1 ug/mL
Beside the measured number, compound 4's estimate is 3.3-fold (0.52 log units) below it, and the stated range covers the measured number.
By their numbers in this assay, from the lowest: compounds 3 and 2 (each within the scatter of the next); then compounds 4 and 1 (each within the scatter of the next).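

Chloro and trifluoromethyl could not be told apart at this aromatic carbon, but phenoxy, which brings a six-membered aromatic ring, does separate from both in this assay with a 4.2-fold higher number from compound 3 to compound 4 (0.62 log units; beyond the scatter) and a 4.0-fold higher number from compound 2 to compound 4 (0.60 log units; beyond the scatter) as its steps. The position therefore responds to some exchanges among these groups and not to others, and phenoxy does not simply extend the earlier trend away from fluoro, since a 1.4-fold lower number from compound 1 to compound 4 (0.15 log units; within the scatter) leaves compound 1 and compound 4 unranked. The data shown offer no measurement that explains these differences.

From the compounds shown here alone, whether the change follows the added ring or the oxygen that links it remains open, and a methoxy or benzyl group at this place would help to separate the two. How an amine or a carboxylic acid would fit among these numbers is also unknown.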